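Anilide series: from propylcarbonyl to (4-aminophenyl)carbonyl

A few compounds are considered here, and "the series" means these few. Any claim that something is new, unique, unknown or untested is made for them only; others in the source may bear on it.

Measured compounds:
compound 1, `CC(=O)c1ccc(OCC(=O)Nc2cccc(NC(=O)c3ccc(N(C)C)cc3)c2)cc1F`, 98 nM
compound 2, `CCCC(=O)Nc1cccc(NC(=O)COc2ccc3c(=O)ccoc3c2)c1`, 176 nM

In an assay on isolated protein for inhibition of Rho-associated protein kinase 2 (Homo sapiens), read by scintillation counting, radiometric assay and 33P incorporation, with a stated time of 40 min, in the presence of a further agent that is not named here (a higher number here means a weaker inhibitor, a lower number a stronger inhibitor), compound 2 gives 176 nM, the higher of the two numbers, though its gap to compound 1 lies within the scatter. Compound 3, `Nc1ccc(C(=O)Nc2cccc(NC(=O)COc3ccc4c(=O)ccoc4c3)c2)cc1`, differs from compound 2 by 4-aminophenyl in place of propyl on a carbonyl carbon. Compound 1 carries an aryl carbonyl on the same amide-type nitrogen and gives 98 nM, so a step of a 1.8-fold lower number from compound 2 to compound 3 (0.25 log units; within the scatter) toward a somewhat lower number is expected, of a size not clearly beyond the scatter. Compound 3 is estimated at 100 nM, with a range from 35 nM to 300 nM.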

Compound 3, half-maximal inhibitory concentration: 83 nM
Beside the measured number, compound 3's estimate is 1.2-fold (0.08 log units) above it, within the range that was stated.
By their numbers in this assay, from the lowest: compounds 3, 1 and 2 (each within the scatter of the next, the first and the last beyond it).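

The carbonyl carbon on the amide-type nitrogen accepts an aromatic ring as well as a short alkyl chain: in this assay, 4-aminophenyl in place of propyl gives a modest step (a 2.1-fold lower number from compound 2 to compound 3 (0.33 log units; beyond the scatter)). Within the data shown here, this is the first comparison that changes one place only, and the larger group costs no inhibition here. Nothing available explains the step.

Still open, on these data alone, is whether the ring or its amino group carries the step, which plain phenyl or 4-(dimethylamino)phenyl on the same core would separate. As far as these compounds go, how a longer alkyl chain or a carboxylic acid reads at this place is also open.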